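Trading a Hydroxy for a Chloro on the Core

A few compounds are considered here, and "the series" means these few. Any claim that something is new, unique, unknown or untested is made for them only; others in the source may bear on it.

Within the data shown here, the study measures growth inhibition of lung cancer cells, and two compounds have numbers so far. Compound 1 `COc1cc2c(/C=C3/C(=O)Nc4ccc(O)cc43)c(Cl)n(Cc3cc(OC)c(OC)c(OC)c3)c2cc1C` gives in a functional assay on NSCLC cells (Homo sapiens) for cytotoxicity, with a stated time of 48 h (a higher number here means a weaker inhibitor of growth, a lower number a stronger inhibitor of growth), a value of 2400 nM. Compound 2 `O=C1Nc2ccccc2/C1=C\c1c(Cl)n(Cc2ccccc2)c2ccccc12` gives in this assay a value of 14800 nM. Compound 1 stands at the lowest of the two numbers, and the gap to compound 2 is beyond the usual scatter, so compound 1 is the stronger inhibitor of growth here.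

Compound 3 `COc1cc2c(/C=C3/C(=O)Nc4ccc(Cl)cc43)c(Cl)n(Cc3cc(OC)c(OC)c(OC)c3)c2cc1C` has not yet been measured in this assay. It differs from compound 1 in one place: chloro in place of hydroxy on an aromatic carbon. The change sits on an aromatic carbon of a six-membered aromatic ring of carbon only, part of a fused system of two rings, meta to a fused ring and para to a fused ring.

Among the measured compounds shown here, no measured pair in this set shows what such a swap does, so the direction is open. The author expects a modest step from compound 1 to compound 3 of a 1.5-fold higher number from compound 1 to compound 3 (0.16 log units; within the scatter), toward a slightly weaker inhibitor, though a step within the scatter would not surprise. The estimate for compound 3 is 3500 nM, with a range from 1200 nM to 12000 nM.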

Compound 3, concentration for 50% growth inhibition: 2290 nM
Compound 3: the middle estimate sits 1.5-fold (0.18 log units) above what was measured; the measured number falls inside the stated range.
By their numbers in this assay, from the lowest: compounds 3 and 1 (each within the scatter of the next); then compound 2.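

Among these compounds, the swap gives the first direct reading at this position, on an aromatic carbon meta to a fused ring and para to a fused ring: in this assay the step is a 1.0-fold lower number from compound 1 to compound 3 (0.02 log units; within the scatter), so the two groups cannot be told apart by this read-out. Hydroxy counts one hydrogen-bond donor and one hydrogen-bond acceptor and chloro counts neither, yet in this single pair that difference in the counts goes with a step inside the scatter, which is something compound 1 and compound 2 alone could not show, since they differ in more than one place. Nothing at hand explains why the two groups read alike in growth inhibition on these cells.

Going by these compounds, whether the same holds for other groups at this place, such as an amine or a carboxylic acid, stays open, as does whether a longer chain there would still read alike. On these data alone, it is also open whether chloro in place of hydroxy would give a similar step on a core carrying a plain benzyl group, as in compound 2, rather than the substituents of compound 1.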